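This account rests on a few compounds, and the source may have more. Where it says the series, first, only, none or still open, it means among the compounds named here.

Measured so far:
compound 1 `CCS(=O)(=O)N[C@H]1CCCN(C(C)=O)[C@H]1CO[C@H]1CC[C@H](C(C)C)CC1`, > 100000 nM
compound 2 `CC(=O)N1CCC[C@H](NS(C)(=O)=O)[C@@H]1CO[C@H]1CC[C@@H](C(C)C)CC1`, > 100000 nM

In a functional assay on CHO-K1 cells for agonist activity at Orexin/Hypocretin receptor type 1 (Homo sapiens), read by FLIPR and calcium flux (on this read-out lower numbers stand for an effect already at smaller amounts and higher numbers for an effect only at larger amounts of compound), compound 1 reaches only the limit of the assay, > 100000 nM, and gives no number. In this assay compound 2 likewise sits at the limit, > 100000 nM, and gives no number. Compound 2 therefore stands at the top edge of the numbers shown, and both values so far are limits; the limit of > 100000 nM in this assay, at which 2 of the 2 values shown sit, gives the position of the whole series. Compound 3 `CC(=O)N1CCC[C@H](N(C)S(C)(=O)=O)[C@@H]1CO[C@H]1CC[C@@H](C(C)C)CC1` differs from compound 2 by methyl in place of hydrogen on a sulfonamide nitrogen. Among the compounds with values here, no measured step exists for such a change, so no direction can be drawn from the data. Compound 3 is expected to stay at the limit as well, with a number no higher from compound 2 to compound 3 (the limit leaves the size open) as the estimated step beyond the scatter only if a number appears. The estimate for compound 3 is 100000 nM, between 20000 nM and 300000 nM.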

Compound 3, half-maximal effective concentration: > 100000 nM
Compound 3 gave a limit, no number (the forecaster's own chance of this, stated with the estimate: 85%); the middle value sits exactly at the limit.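

In this assay no step can be read from compound 2 to compound 3, whose values are both limits and not numbers. The compounds shown leave open whether methyl in place of hydrogen on a sulfonamide nitrogen changes anything, and whether any compound of this series gives a number: the limit of > 100000 nM in this assay, at which 3 of the 3 values shown sit.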